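Three Limit Values and One Protecting-Group Change

This account rests on a few compounds, and the source may have more. Where it says the series, first, only, none or still open, it means among the compounds named here.

Of the compounds shown here, three have been measured in a functional assay on ECa-109 cells (Homo sapiens) for inhibition, read by MTT assay, with a stated time of 72 h; a higher number here means a weaker inhibitor, a lower number a stronger inhibitor. Compound 1 `S=C(SCc1cn(Cc2ccc(Cl)c(Cl)c2)nn1)N1CCNCC1` gives > 128000 nM, which is a limit of the assay rather than a number. Compound 2 `CC(C)(C)OC(=O)N1CCN(C(=S)SCc2cn(Cc3ccc(Cl)c(Cl)c3)nn2)CC1` gives > 128000 nM, again a limit. Compound 3 `COc1cc(Cn2cc(CSC(=S)N3CCNCC3)nn2)cc(OC)c1OC` gives > 128000 nM, also a limit.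

From compound 1 to compound 2 the change is tert-butoxycarbonyl in place of hydrogen on an amine nitrogen in a ring, and the step that the two limits leave unreadable from compound 1 to compound 2 cannot be read, since both ends are limits. Compound 4 `COc1cc(Cn2cc(CSC(=S)N3CCN(C(=O)OC(C)(C)C)CC3)nn2)cc(OC)c1OC` is not yet measured; against compound 3 it carries the same change, (tert-butoxycarbonyl in place of hydrogen on an amine nitrogen in a ring), at a place described in the same words. The difference between the cores of compound 1 and compound 3 is not broken down here.

Because the limit of > 128000 nM in this assay, at which 3 of the 3 values shown sit, holds every value shown, the step is expected to be a step that the limit leaves unreadable from compound 3 to compound 4. Compound 4 is estimated to give 200000 nM, most likely again only a limit.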

Compound 4, half-maximal inhibitory concentration: 44400 nM
Estimate against measurement, compound 4: 4.5-fold (0.65 log units) above; measured number below the stated range.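

In this assay, putting tert-butoxycarbonyl in place of hydrogen on an amine nitrogen in a ring gives an at least 2.8-fold lower number from compound 3 to compound 4 (0.45 log units; beyond the scatter), so on the core of compound 3 the change yields a stronger inhibitor. The same change on the core of compound 1 cannot be read because both ends of that step are limits: the limit of > 128000 nM in this assay, at which 3 of the 4 values shown sit. The result therefore rests on one core only, and it does not show whether the change carries over to the core of compound 1 or how large it would be there.

Still open, going by these compounds, is whether tert-butoxycarbonyl itself matters. A smaller acetyl or a methyl group on the same amine nitrogen might do the same.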